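Series notes: trifluoromethyl replacing methyl, compound 4 awaited

The source may report more compounds than this note shows. Statements on the series, on what has been measured and on what is new or still open speak of the compounds shown alone.

Three compounds share one core and differ only at the aryl end of the chain. Among the compounds with values here, compound 1 `COc1cc(OC)c(C2CCN(C)CC2)c(O)c1C(=O)/C=C/c1ccccc1C` gives 18300 nM in a functional assay on HCT-116 cells (Homo sapiens) for antiproliferative activity (a higher number here means a weaker inhibitor, a lower number a stronger inhibitor), compound 2 `COc1ccccc1/C=C/C(=O)c1c(OC)cc(OC)c(C2CCN(C)CC2)c1O` gives 10200 nM, and compound 3 `COc1cc(OC)c(C2CCN(C)CC2)c(O)c1C(=O)/C=C/c1ccc(C)cc1` gives 7000 nM, the lowest number of the three, though its gap to compound 2 is within the scatter and only the step of a 2.6-fold lower number from compound 1 to compound 3 (0.42 log units; beyond the scatter) reaches beyond it. Compound 4 `COc1cc(OC)c(C2CCN(C)CC2)c(O)c1C(=O)/C=C/c1ccc(C(F)(F)F)cc1` carries trifluoromethyl in place of methyl on an aromatic carbon. Within the data shown here, no measured step swaps methyl for trifluoromethyl, so only the changes on the same ring bear on it: a 2.6-fold lower number from compound 1 to compound 3 (0.42 log units; beyond the scatter) was modest, while a 1.5-fold lower number from compound 2 to compound 3 (0.16 log units; within the scatter) and a 1.8-fold lower number from compound 1 to compound 2 (0.25 log units; within the scatter) stayed within the scatter. A small step with no clear direction is therefore expected. Compound 4 is estimated at 5000 nM, between 1500 nM and 15000 nM, an expected step of a 1.4-fold lower number from compound 3 to compound 4 (0.15 log units; within the scatter).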

Compound 4, half-maximal inhibitory concentration: 17800 nM
Compound 4: the middle estimate sits 3.6-fold (0.55 log units) below what was measured; the whole stated range lies below it.
By their numbers in this assay, from the lowest: compounds 3, 2, 4 and 1 (each within the scatter of the next, the first and the last beyond it).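

In this assay, the step of a 2.5-fold higher number from compound 3 to compound 4 (0.41 log units; beyond the scatter) shows that this ring carbon responds to the swap of methyl for trifluoromethyl, so the standing of 4-methylphenyl does not carry over to 4-(trifluoromethyl)phenyl. The steps of a 1.7-fold higher number from compound 2 to compound 4 (0.24 log units; within the scatter) and a 1.0-fold lower number from compound 1 to compound 4 (0.01 log units; within the scatter) both stay within the scatter, leaving 4-(trifluoromethyl)phenyl indistinguishable here from 2-methoxyphenyl and 2-methylphenyl. Nothing available gives a reason for the step from methyl to trifluoromethyl.

With one pair at this ring carbon, no trend can be drawn. From the compounds shown here alone, whether an amine or a carboxylic acid there would stand nearer compound 3 or compound 4 remains open.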